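The compounds below may be only part of what the source reports. "The series", "measured", "known", "first", "only" and "open" are said of these compounds alone.

Notes on the series. Compound 1 `C[C@H](Nc1nc(N)nc(N)c1C#N)c1nn(-c2cccc(S(C)(=O)=O)c2)c2cc(F)ccc12` carries the 3-(methylsulfonyl)phenyl group on an aromatic nitrogen and a different core from the others; in a functional assay on HepG2 cells (Homo sapiens) for inhibition, read by sulforhodamine B assay, with a stated time of 72 h, tested at 10 uM (a lower number here means less inhibition, a higher number more inhibition at the concentration tested (going by the name of the read-out)), compound 1 gives 24%. Compound 2 `C[C@H](Nc1ncnc2[nH]cnc12)c1nn(-c2cccnc2)c2cc(F)ccc12` and compound 3 `C[C@H](Nc1ncnc2[nH]cnc12)c1nn(-c2ccccn2)c2cc(F)ccc12` share the second core and differ only in the group on the aromatic nitrogen; in this assay compound 2 gives 23% and compound 3 gives 22%. Going by the values given here, the one measured step, a number 1 percentage points lower from compound 2 to compound 3 (within the scatter), lies within the scatter. Compound 3 stands with the lowest of the three numbers, but its gaps to compound 2 and to compound 1 are both within the scatter, so no order can be read among them.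

Compound 4 `C[C@H](Nc1ncnc2[nH]cnc12)c1nn(-c2cccc(S(C)(=O)=O)c2)c2cc(F)ccc12` is not yet measured. The change from compound 3 is 3-(methylsulfonyl)phenyl in place of pyridin-2-yl on an aromatic nitrogen. The step that bears on it is the aryl swap on the same nitrogen, which was within the scatter; in addition compound 1, which already carries the entering group on a different core, gives a number within the scatter of compound 3. No step beyond the scatter is therefore expected in this assay, and the expected step of a number 2 percentage points higher from compound 3 to compound 4 (within the scatter) is small. Compound 4 is expected to give 24%, with a range from 12% to 36%.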

Compound 4, a percentage reported as inhibition, at one concentration (the size of the read-out at that concentration, not a potency): 23%
Compound 4: the middle estimate sits 1 percentage points above what was measured, within the range that was stated.
By their numbers in this assay, from the lowest: compounds 3, 2, 4 and 1 (each within the scatter of the next).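

On the aromatic nitrogen of the shared core, a group of 10 heavy atoms with a carbon-only aromatic ring, 3-(methylsulfonyl)phenyl, can stand in place of either pyridine of 6 heavy atoms without a step beyond the scatter in this assay (a number 1 percentage points higher from compound 3 to compound 4 (within the scatter); no change at the digits printed from compound 2 to compound 4 (within the scatter)). Pyridin-2-yl, pyridin-3-yl and 3-(methylsulfonyl)phenyl therefore cannot be told apart at this position in this assay, whereas the earlier step compared only the two pyridines. Going by these compounds alone, with 3-(methylsulfonyl)phenyl held the same, the exchange of the group on the amine nitrogen can now be read directly for the first time, and it too lies within the scatter (a number 1 percentage points lower from compound 1 to compound 4 (within the scatter)).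

No measured evidence bears on these results. Still open, from the compounds shown here alone, is whether an amine or a carboxylic acid on the aromatic ring of this group, or a longer chain in place of the ring on the aromatic nitrogen, would give a step beyond the scatter in this assay.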